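This account rests on a few compounds, and the source may have more. Where it says the series, first, only, none or still open, it means among the compounds named here.

Compound 1 `COc1nn(C(C)C)c2ncnc(NS(=O)(=O)c3cccc(Cl)c3Cl)c12`: 4.5
Compound 2 `COc1nn(CC(N)=O)c2ncnc(NS(=O)(=O)c3cccc(Cl)c3Cl)c12`: 1.1

In a physicochemical assay for lipophilicity (a lower number here means a more polar compound, a higher number a more lipophilic compound), compound 2 stands lowest of the two measured compounds; compound 1 sits above it by a number 3.40 log units lower from compound 1 to compound 2 (beyond the scatter). Compound 3 `COCCn1nc(OC)c2c(NS(=O)(=O)c3cccc(Cl)c3Cl)ncnc21` differs from compound 2 in one place: methoxymethyl in place of carbamoyl on a saturated chain carbon bound to an aromatic nitrogen. Among the compounds with values here, the only measured step that bears on this change is the one from compound 1 to compound 2, which amounted to a number 3.40 log units lower from compound 1 to compound 2 (beyond the scatter). Compound 3 keeps a chain of the same length but not the carbamoyl group, so an upward step of a number 1.70 log units higher from compound 2 to compound 3 (beyond the scatter) is expected, smaller than that earlier step. For compound 3 an estimated value of 2.8 is expected, within 2.1 to 3.5.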

Compound 3, distribution coefficient: 2.6
Compound 3: middle estimate off by 0.20 log units, on the high side, within the range that was stated.
By their numbers in this assay, from the lowest: compound 2; then compound 3; then compound 1.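

In this assay the change to methoxymethyl in place of carbamoyl on a saturated chain carbon bound to an aromatic nitrogen gives a number 1.50 log units higher from compound 2 to compound 3 (beyond the scatter) and shows that the number moves at this position even when the replacing group has the same count of heavy atoms. Using 2-methoxyethyl in place of isopropyl still gives a number 1.90 log units lower from compound 1 to compound 3 (beyond the scatter) and so places compound 3 between the two earlier compounds. No measurement shown explains why these numbers moved. Going by these compounds, how an amine, a carboxylic acid or a longer chain at this position would compare remains open.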